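Notes on the Step from Compound 2 to Compound 3

This account rests on a few compounds, and the source may have more. Where it says the series, first, only, none or still open, it means among the compounds named here.

Measured so far:
compound 2, `NC[C@@H]1CCN(c2cc3c(cc2F)c(=O)c(C(=O)O)cn3Cc2ccc(-c3ccc(F)cc3)cc2)C1`: 69600 nM
compound 1, `O=C(O)c1cn(Cc2ccc(-c3ccccc3)cc2)c2cc(NC[C@H]3CCNC3)c(F)cc2c1=O`: 100000 nM

In an assay on isolated protein for inhibition of DNA topoisomerase 1 (Homo sapiens), with a stated time of 15 min (a lower number here means a stronger inhibitor, a higher number a weaker inhibitor), compound 2 gives 69600 nM, the lowest of the two numbers available. In this assay compound 1 gives 100000 nM, which lies within the scatter of the value of compound 2, so no order between the two can be read. Both numbers are high, and neither compound is a strong inhibitor here.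

Compound 3, `NC[C@@H]1CCN(c2cc3c(cc2F)c(=O)c(C(=O)O)cn3Cc2ccc(-c3ccccc3)cc2)C1`, has not yet been measured. It differs from compound 2 by hydrogen in place of fluoro on an aromatic carbon of a six-membered aromatic ring of carbon only, para to a large group; cut one bond further out, the change reads 4-fluorophenyl to phenyl. Among the compounds with values here, no step between measured compounds that differ in one place exists, so the size of such a change is not known from the data. The expected step is none beyond the scatter, a 1.1-fold higher number from compound 2 to compound 3 (0.06 log units; within the scatter). Compound 3 is therefore estimated at 80000 nM, with a range from 30000 nM to 200000 nM.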

Compound 3, half-maximal inhibitory concentration: 15600 nM
Estimate against measurement, compound 3: 5.1-fold (0.71 log units) above; the measured number lies below the stated range.
By their numbers in this assay, from the lowest: compound 3; then compounds 2 and 1 (each within the scatter of the next).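

In this assay, within the data shown here, the aromatic position para to a large group proves not to be silent: hydrogen in place of fluoro on an aromatic carbon, read further out as 4-fluorophenyl to phenyl, gives a 4.5-fold lower number from compound 2 to compound 3 (0.65 log units; beyond the scatter) and is the first single change whose size can be read. With the phenyl end held constant, the link to the core also counts, as 3-(aminomethyl)pyrrolidin-1-yl in place of ((pyrrolidin-3-yl)methyl)amino gives a 6.4-fold lower number from compound 1 to compound 3 (0.81 log units; beyond the scatter) on the same aromatic carbon. No measurement in hand explains either step.

As far as these compounds go, whether other groups at the para position, such as chloro, methyl or methoxy, would behave like hydrogen or like fluoro remains open. Also open, from the compounds shown here alone, is how a methyl ester or a primary amide in place of the carboxylic acid would read.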